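Hydroxy in place of trifluoromethyl on compound 2

A few compounds are considered here, and "the series" means these few. Any claim that something is new, unique, unknown or untested is made for them only; others in the source may bear on it.

Within the data shown here, compound 2 `O=C(Nc1ccccc1C(F)(F)F)C1CCc2ccccc2N1C(=O)c1cccc(Cl)c1` is one of three compounds measured in a functional assay on ACHN cells (Homo sapiens) for cytotoxicity, read by sulforhodamine B assay, with a stated time of 72 h; on this read-out higher numbers stand for weaker inhibition of growth and lower numbers for stronger inhibition of growth. In this assay compound 2 gives 526 nM, the lowest of the two plain numbers reported. Compound 3 `O=C(Nc1ccccc1C(F)(F)F)C1CCc2ccccc2N1C(=O)c1ccc(Cl)cc1` gives 824 nM in this assay, and the step of a 1.6-fold higher number from compound 2 to compound 3 (0.19 log units; within the scatter) lies within the scatter, so the two cannot be ordered against each other. Compound 1 `CCC(=O)N1c2ccccc2CCC1C(=O)Nc1ccccc1C(F)(F)F` is reported in this assay only as a limit, > 80000 nM. Measured from that limit (the limit of > 80000 nM in this assay, at which 1 of the 3 values shown sits), the steps of an at least 150-fold lower number from compound 1 to compound 2 (2.18 log units; beyond the scatter) and an at least 97-fold lower number from compound 1 to compound 3 (1.98 log units; beyond the scatter) are both large.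

Compound 4 `O=C(Nc1ccccc1O)C1CCc2ccccc2N1C(=O)c1cccc(Cl)c1` differs from compound 2 at another place: hydroxy in place of trifluoromethyl on an aromatic carbon. None of the three measured steps touches that ring; each of them changes the group on the carbonyl carbon of the shared core. The measured steps therefore give no direct guide to the size or direction of the step to compound 4, and the expectation carries a wide range. Compound 4 is expected to give about 2500 nM in this assay, within a range from 400 nM to 25000 nM. The expected step of a 4.8-fold higher number from compound 2 to compound 4 (0.68 log units; beyond the scatter) is estimated with little confidence, and a number beyond the reported limit cannot be excluded.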

Compound 4, concentration for 50% growth inhibition: 17200 nM
Compound 4: middle estimate off by 6.9-fold (0.84 log units), on the low side; the measured number falls inside the stated range.
By their numbers in this assay, from the lowest: compounds 2 and 3 (each within the scatter of the next); then compound 4. At a limit, above all of these: compound 1.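

Until compound 4, every measured step in this assay had changed the group on the carbonyl carbon of the shared core, while the 2-(trifluoromethyl)phenyl group stayed the same throughout. The step of a 33-fold higher number from compound 2 to compound 4 (1.51 log units; beyond the scatter) shows that the number also responds strongly to a change at this other place, even with the 3-chlorophenyl group held constant, so the activity of compound 2 does not depend on the carbonyl substituent alone. No measurement shown bears on the cause of this step, and it cannot be said whether the loss of trifluoromethyl, the arrival of hydroxy, or both account for it.

With only trifluoromethyl and hydroxy shown on this aromatic carbon, the compounds leave open how a methoxy group, a chlorine atom, an amine or a plain hydrogen there would read in this assay. They also leave open whether hydroxy in place of trifluoromethyl would shift the number by a similar amount on compound 3, which carries 4-chlorophenyl on the carbonyl carbon.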